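The source may hold more compounds than are shown below. What is called first, only, known or untested is meant among the compounds shown, and "the series" means these compounds.

Compound 1, `COc1ccc(/C=N/NC(=S)N/N=C2\C(=O)Nc3ccc(C)cc32)cc1O`: in a functional assay on HeLa cells (Homo sapiens) for inhibition, read by MTT assay (a higher number here means a weaker inhibitor, a lower number a stronger inhibitor), compound 1 gives 2730 nM.
Compound 2, `O=C1Nc2ccc(Br)cc2/C1=N/NC(=S)N/N=C/c1ccc2ccccc2c1`: in this assay compound 2 gives only a limit of the assay, > 50000 nM.
Compound 3, `COc1ccc(/C=N/NC(=S)N/N=C2\C(=O)Nc3ccc(Br)cc32)c(OC)c1`: in this assay compound 3 likewise gives only a limit of the assay, > 50000 nM.

Compound 3 therefore stands at the edge of what this assay reports, not at a number, and it shares that position with compound 2, as the limit of > 50000 nM in this assay, at which 2 of the 3 values shown sit, records. Only compound 1 gives a measurable value among the three. Compound 4, `COc1ccc(/C=N/NC(=S)N/N=C2\C(=O)Nc3ccc(C)cc32)c(OC)c1`, differs from compound 3 by methyl in place of bromo on an aromatic carbon. For the measured compounds named here, no measured pair isolates this change. Compound 1, which also carries methyl on that ring, gives 2730 nM. Compound 2 and compound 3, the two bromo-bearing compounds, return only a limit of the assay each; this rests on three compounds and nothing more. Compound 4 is estimated at 15000 nM, within 3000 nM to 50000 nM. The expected step is an at least 3.3-fold lower number from compound 3 to compound 4 (0.52 log units; beyond the scatter), toward a stronger inhibitor, though a further limit remains quite possible.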

Compound 4, half-maximal inhibitory concentration: > 50000 nM
Compound 4: a limit, no number (the forecaster's own chance of this, stated with the estimate: 40%); middle value at least 3.3-fold (0.52 log units) away from the limit.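

Compound 4, like compound 3, gives only a limit in this assay, so no step between the two can be read: the limit of > 50000 nM in this assay, at which 3 of the 4 values shown sit.

The compounds shown leave open whether methyl in place of bromo on an aromatic carbon changes inhibition at all.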